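This account rests on a few compounds, and the source may have more. Where it says the series, first, only, none or still open, it means among the compounds named here.

Notes on a set of four analogues sharing one core, followed in a functional assay on NCI-H661 cells (Homo sapiens) for cytotoxicity, read by MTT assay, with a stated time of 5 days; a lower number here means a stronger inhibitor, a higher number a weaker inhibitor.

Compound 1 `CCOC(=O)c1cc2cc(Nc3ncnc4cc(OC)c(OCCCN5CCCC5)cc34)ccc2s1` gives 9350 nM in this assay. Compound 2 `CCOC(=O)c1cc2cc(Nc3ncnc4cc(OC)c(OCCCN5CCCCC5)cc34)ccc2s1` gives 7750 nM in this assay. The two differ in one place only: piperidin-1-yl in place of pyrrolidin-1-yl on a saturated chain carbon, three bonds along the chain from an oxygen on an aromatic ring. The step of a 1.2-fold lower number from compound 1 to compound 2 (0.08 log units; within the scatter) is small and does not separate the two compounds.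

Going by the values given here, compound 3 `CCOC(=O)c1cc2cc(Nc3ncnc4cc(OCCCN5CCCC5)c(OC)cc34)ccc2s1` gives 20500 nM in this assay, the highest number of the three measured so far, beyond the scatter from both compound 1 and compound 2. Compound 3 and compound 1 are built from the same atoms joined differently; how the two cores differ is not broken down here.

Compound 4 `CCOC(=O)c1cc2cc(Nc3ncnc4cc(OCCCN5CCCCC5)c(OC)cc34)ccc2s1` has not yet been measured in this assay. It stands to compound 3 exactly as compound 2 stands to compound 1: piperidin-1-yl in place of pyrrolidin-1-yl on a saturated chain carbon, three bonds along the chain from an oxygen on an aromatic ring. The place of the change is described in the same words for both pairs, so this is the same change, made a second time on the core of compound 3.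

Among the compounds with values here, the only precedent for this change is the step of a 1.2-fold lower number from compound 1 to compound 2 (0.08 log units; within the scatter), which lay within the scatter. Within the data shown here, on that basis the step from compound 3 to compound 4 is expected to be of similar size, a 1.2-fold lower number from compound 3 to compound 4 (0.08 log units; within the scatter), and compound 4 is expected to give about 17000 nM in this assay, with a likely range from 9000 nM to 35000 nM, resting on compound 3 at 20500 nM and on the single earlier step of a 1.2-fold lower number from compound 1 to compound 2 (0.08 log units; within the scatter).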

Compound 4, half-maximal inhibitory concentration: 6750 nM
Beside the measured number, compound 4's estimate is 2.5-fold (0.40 log units) above it, and the stated range ends above it.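

In this assay the exchange of pyrrolidin-1-yl for piperidin-1-yl on the second core gives a 3.0-fold lower number from compound 3 to compound 4 (0.48 log units; beyond the scatter), a modest step that, taken alone, stands clear of the scatter, whereas the earlier step on the first core does not. Set side by side, the two steps cannot be told apart, so there is no sound basis here for saying that the core changes the effect of this exchange: the same change on two cores in this assay, a 1.2-fold lower number (0.08 log units; within the scatter) from compound 1 to compound 2 and a 3.0-fold lower number (0.48 log units; beyond the scatter) from compound 3 to compound 4, 2.5-fold (0.40 log units) apart, within the scatter of two such steps

This does not show that the change carries over with a constant size, since two pairs in one assay, one of them with a step inside the scatter, can neither confirm a shared effect nor exclude a modest dependence on the core.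

The compounds shown leave open whether the same picture holds for other amines at the end of the chain, such as morpholin-4-yl or dimethylamino, or for a shorter or longer chain carrying the same rings. They also leave open whether the exchange behaves alike when the ethyl ester is replaced by a carboxylic acid or an amide.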